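Metabolic stability in rat lung: pyridinylmethyl to isobutyl amine

The source may hold more compounds than are shown below. What is called first, only, known or untested is meant among the compounds shown, and "the series" means these compounds.

Of the compounds shown here, two have been measured so far. Compound 1 `Cc1csc2cc([C@H](C)Nc3ncnc(N)c3C#N)c(-c3cccc(CN4CCC(CN(C)Cc5ccccn5)CC4)c3)c(=O)n12` is read in an ADME assay on the whole organism (lung, Rattus norvegicus) for metabolic stability, read by LC-MS, with a stated time of 24 h (on this read-out lower numbers stand for a less stable compound and higher numbers for a more stable compound), at 5.2%. Compound 2 `Cc1csc2cc([C@H](C)Nc3ncnc(N)c3C#N)c(Cc3cccc(CN(C)CC(C)C)c3)c(=O)n12`, which carries a methylene linker and an isobutyl(methyl)amino group in place of the piperidine-bearing aryl, gives in this assay a value of 0%. The two values lie within the scatter of each other, so nothing distinguishes compound 1 from compound 2 on this read-out; both sit at the low end of the scale.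

Compound 3 `Cc1csc2cc([C@H](C)Nc3ncnc(N)c3C#N)c(-c3cccc(CN4CCC(CN(C)CC(C)C)CC4)c3)c(=O)n12` has not been measured. It differs from compound 1 in one place: isopropyl in place of pyridin-2-yl on a saturated chain carbon bound to an amine nitrogen. Among the measured compounds shown here, no measured pair in the set shares this exact difference, so no step size can be read off directly.

Given that compound 1 gives 5.2% and compound 2 gives 0%, with both at the low end, the step from compound 1 to compound 3 is expected to be small, a number 2.2 percentage points lower from compound 1 to compound 3 (within the scatter), and not beyond the scatter. Compound 3 is therefore estimated at 3%, with a range from 0% to 12%.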

Compound 3, percent of the compound remaining in the lung assay: 3.3%
Compound 3: the middle estimate sits 0.3 percentage points below what was measured, and the stated range covers the measured number.
By their numbers in the lung assay, from the lowest: compounds 2, 3 and 1 (each within the scatter of the next).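

Among the compounds shown here, in the lung assay, the change of pyridin-2-yl to isopropyl on a saturated chain carbon bound to an amine nitrogen gives the first one-place comparison, and it reads a number 1.9 percentage points lower from compound 1 to compound 3 (within the scatter), so this change does not tell the two compounds apart on stability. In a physicochemical assay for acid dissociation, compound 1 gives 7 and compound 3 gives 8, and the same change does register on this read-out, as a number 1.00 log units higher from compound 1 to compound 3 (beyond the scatter). For this pair, then, a difference on the physicochemical assay comes with no readable difference on the lung assay, and both compounds stay at the low end of the scale.

On these data alone, whether a phenyl, a cyclopropyl or a carboxylic acid in this place would move the number off the low end stays open, since a single pair gives one step and no trend. The compounds shown also do not tell which part of the shared structure sets the low numbers, and compound 2 differs from compound 1 in more than one place, so it adds no clean comparison.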